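A few compounds are considered here, and "the series" means these few. Any claim that something is new, unique, unknown or untested is made for them only; others in the source may bear on it.

Measured compounds:
Compound 1 `COc1ccc(C#N)cc1CSc1nc2cc(NC(=O)C3CC3)ccc2n1C(C)C` — in an assay on isolated protein for inhibition of Gonadotropin-releasing hormone receptor (Rattus norvegicus) (a higher number here means a weaker inhibitor, a lower number a stronger inhibitor), compound 1 gives > 10000 nM.
Compound 2 `COc1ccc([N+](=O)[O-])cc1CSc1nc2cc(NC(=O)NC(C)(C)C)ccc2n1C1CC1` — in this assay compound 2 gives 860 nM.
Compound 3 `COCCn1c(SCc2cc([N+](=O)[O-])ccc2OC)nc2cc(NC(=O)NC(C)(C)C)ccc21` — in this assay compound 3 gives 280 nM.

The value of compound 1 is a limit of this assay, not a number; it sits at the limit of > 10000 nM in this assay, at which 1 of the 3 values shown sits. Compound 3 has the lowest of the two numbers shown, with compound 2 its nearest neighbour, separated by a 3.1-fold lower number from compound 2 to compound 3 (0.49 log units; beyond the scatter), a modest step that arose from the exchange on the aromatic nitrogen.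

Compound 4 `COc1ccc([N+](=O)[O-])cc1CSc1nc2cc(NC(=O)NC(C)(C)C)ccc2n1Cc1ccncc1` is not yet measured. It differs from compound 3 in one place: pyridin-4-yl in place of methoxymethyl on a saturated chain carbon bound to an aromatic nitrogen. Within the data shown here, the only measured step that bears on this position is the one from compound 2 to compound 3, and it was modest. Compound 1 differs from the others in several places, so its limit does not tell how a single exchange acts. A second exchange at the same nitrogen is therefore expected to give a step of about a 1.1-fold lower number from compound 3 to compound 4 (0.05 log units; within the scatter), within or just beyond the scatter, with no firm direction. Compound 4 is estimated at 250 nM, likely between 70 nM and 900 nM.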

Compound 4, half-maximal inhibitory concentration: 240 nM
Estimate against measurement, compound 4: 1.0-fold (0.02 log units) above, and the stated range covers the measured number.
By their numbers in this assay, from the lowest: compounds 4 and 3 (each within the scatter of the next); then compound 2. At a limit, above all of these: compound 1.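

In this assay, the exchange at this position brings in a larger group with a six-membered aromatic ring, yet pyridin-4-yl in place of methoxymethyl on the saturated chain carbon gives a 1.2-fold lower number from compound 3 to compound 4 (0.07 log units; within the scatter), so the ring and the open ether chain cannot be told apart here. Measured against cyclopropyl on the aromatic nitrogen, (pyridin-4-yl)methyl gives a 3.6-fold lower number from compound 2 to compound 4 (0.55 log units; beyond the scatter), which shows that compound 3 is not alone in standing apart from compound 2 and that two quite different groups on this nitrogen reach similar values. Nothing among the data shown explains why these two groups give such similar values.

On these data alone, what an amine-bearing chain, a carboxylic acid or a longer chain on this nitrogen would give remains open. So does the effect of moving the ring nitrogen, as in pyridin-3-yl or pyridin-2-yl.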